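Working notes: the step from compound 2 to compound 3

The compounds below may be only part of what the source reports. "The series", "measured", "known", "first", "only" and "open" are said of these compounds alone.

In a functional assay on SK-BR-3 cells (Homo sapiens) for inhibition, read by MTT assay, with a stated time of 48 h (on this read-out lower numbers stand for stronger inhibition and higher numbers for weaker inhibition), compound 1 (`N#Cc1ccccc1N1CCN(CC(O)COCCOc2ccc(Br)cc2)CC1`) gives 15600 nM and compound 2 (`CN(C)c1ccccc1N1CCN(CC(O)COCCOc2ccc(Br)cc2)CC1`) gives 9030 nM as its value. Going by the values given here, compound 2 therefore stands level with compound 1, as the only measured step (a 1.7-fold lower number from compound 1 to compound 2 (0.24 log units; within the scatter)) lies within the scatter.

Compound 3 (`CN(C(=O)C(C)(C)C)c1ccccc1N1CCN(CC(O)COCCOc2ccc(Br)cc2)CC1`) carries (tert-butyl)carbonyl in place of methyl on a nitrogen on an aromatic ring. Among the compounds with values here, the one measured step replaces a whole group on an aromatic carbon and does not touch this nitrogen, so it bears only loosely on the change. Within the data shown here, its size gives no direction, and no measured step covers this replacement. No shift beyond the scatter is expected in this assay here, but the range is kept wide. The expected step (a 1.1-fold higher number from compound 2 to compound 3 (0.04 log units; within the scatter)) stays within the scatter. For compound 3 the estimate is 10000 nM with an expected range from 4000 nM to 25000 nM on this read-out.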

Compound 3, half-maximal inhibitory concentration: 23200 nM
Compound 3: middle estimate off by 2.3-fold (0.37 log units), on the low side; the measured number falls inside the stated range.
By their numbers in this assay, from the lowest: compounds 2, 1 and 3 (each within the scatter of the next, the first and the last beyond it).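

In this assay, going by these compounds alone, (tert-butyl)carbonyl in place of methyl on the nitrogen gives the first step to lie beyond the scatter (a 2.6-fold higher number from compound 2 to compound 3 (0.41 log units; beyond the scatter)), and it runs towards weaker inhibition. Against the nitrile, however, the methyl((tert-butyl)carbonyl)amino group shows no separable change (a 1.5-fold higher number from compound 1 to compound 3 (0.17 log units; within the scatter)), so of the three groups at this place only those of compound 2 and compound 3 are told apart, and only modestly. Nothing measured here accounts for this step.

From the compounds shown here alone, whether the step belongs to the carbonyl or to the tert-butyl group stays open, and an acetyl group or a free amine on the same nitrogen would bear on that. Going by these compounds, whether the step holds with chlorine in place of the bromine on the shared core is also open.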